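The source may hold more compounds than are shown below. What is called first, only, known or untested is meant among the compounds shown, and "the series" means these compounds.

Working notes on the hydroxamic series sharing the core of compound 1 `COc1cccc(OC)c1C(=O)N(O)C(C)c1ccc2oc(-c3ccccc3)cc2c1`, in which only the group on the carbonyl carbon is varied. In an assay on RBL cells for inhibition of Polyunsaturated fatty acid 5-lipoxygenase (Rattus norvegicus) (on this read-out lower numbers stand for stronger inhibition and higher numbers for weaker inhibition), compound 1 gives 3000 nM. Compound 2 `CC(c1ccc2oc(-c3ccccc3)cc2c1)N(O)C(=O)c1ccco1` gives 40 nM in this assay, and compound 3 `CC(c1ccc2oc(-c3ccccc3)cc2c1)N(O)C(=O)c1cccs1` gives 250 nM. Compound 3 therefore stands second highest of the three numbers: the nearest is compound 2, separated by a 6.3-fold higher number from compound 2 to compound 3 (0.80 log units; beyond the scatter), the furthest is compound 1, separated by a 12-fold lower number from compound 1 to compound 3 (1.08 log units; beyond the scatter).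

Compound 4 `CC(=O)OCC(=O)N(O)C(C)c1ccc2oc(-c3ccccc3)cc2c1` differs from compound 3 by acetoxymethyl in place of thiophen-2-yl on a carbonyl carbon. The three measured steps all bear on this position. Replacing the 2,6-dimethoxyphenyl with either five-membered ring moved the number a long way, a 75-fold lower number from compound 1 to compound 2 (1.88 log units; beyond the scatter) and a 12-fold lower number from compound 1 to compound 3 (1.08 log units; beyond the scatter), while exchanging one ring for the other gave a 6.3-fold higher number from compound 2 to compound 3 (0.80 log units; beyond the scatter). Within the data shown here, every measured group here is aromatic, so no step shows what an open-chain acetoxymethyl does; the direction is open. Given that every change at this carbonyl so far has moved the number beyond the scatter, a step beyond the scatter is expected for compound 4, most plausibly toward a higher number since the aromatic ring is lost, a 2.4-fold higher number from compound 3 to compound 4 (0.38 log units; beyond the scatter). Compound 4 is estimated at 600 nM, within 120 nM to 3000 nM.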

Compound 4, half-maximal inhibitory concentration: 160 nM
Compound 4: the middle estimate sits 3.8-fold (0.57 log units) above what was measured; measured number inside the range.
By their numbers in this assay, from the lowest: compound 2; then compounds 4 and 3 (each within the scatter of the next); then compound 1.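

Acetoxymethyl on this carbonyl carbon carries no ring, yet in this assay it gives (a 19-fold lower number from compound 1 to compound 4 (1.27 log units; beyond the scatter)), and its difference from thiophen-2-yl stays within the scatter (a 1.6-fold lower number from compound 3 to compound 4 (0.19 log units; within the scatter)). An aromatic ring at this position is therefore not needed to reach this range, and aromatic character alone does not sort the series: compound 1 also carries an aromatic ring and has the highest number of the four. Furan-2-yl keeps its separation from the open-chain group (a 4.0-fold higher number from compound 2 to compound 4 (0.60 log units; beyond the scatter)), so compound 2 remains the lowest, though nothing at hand accounts for any of these steps.

Going by these compounds, it remains open whether the reading of compound 4 belongs to the open chain as such or to its ester, a question that a plain methyl, a hydroxymethyl or a longer alkyl chain on this carbonyl carbon would address. On these data alone, how an amine or a carboxylic acid at the end of such a chain would read in this assay is equally open.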